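Amide aryl swap in the cyanopyridine series

A few compounds are considered here, and "the series" means these few. Any claim that something is new, unique, unknown or untested is made for them only; others in the source may bear on it.

Compound 1 `Cc1cc(C#N)cnc1C(=O)Nc1ccc(F)c([C@]2(C)C=C(CF)OC(N)=N2)c1` is the reference point of the two measured compounds. In a physicochemical assay for lipophilicity, read by HPLC, in phosphate buffer, measured as octanol-water partition, with a stated time of 1 h, at pH 7.4 (a higher number here means a more lipophilic compound, a lower number a more polar compound), compound 1 gives 2.5, the highest of the two numbers recorded. Compound 2 `C[C@@]1(c2cc(NC(=O)c3ccc(C#N)cn3)ccc2F)C=COC(N)=N1` is the nearest neighbour; in this assay compound 2 gives 2, a value that sits lower than compound 1, beyond the scatter of the method. Among the measured compounds shown here, compound 2 differs from compound 1 in more than one place, so no single-point step between the two is available.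

Compound 3 `C[C@@]1(c2cc(NC(=O)c3coc(CF)n3)ccc2F)C=C(CF)OC(N)=N1` is the unmeasured compound. Its difference from compound 1 is as follows: 2-(fluoromethyl)-1,3-oxazol-4-yl in place of 5-cyano-3-methylpyridin-2-yl on a carbonyl carbon. The carbonyl carbon at which the exchange occurs is otherwise bound to the amide-type nitrogen, and the rest of the shared core is unchanged.

For the measured compounds named here, no measured pair isolates this exchange, so the expectation rests on the two recorded values alone. A downward step is expected from compound 1 to compound 3, a number 0.60 log units lower from compound 1 to compound 3 (beyond the scatter), of a size beyond the usual scatter. The value expected for compound 3 in this assay is 1.9, with a range from 1.4 to 2.4.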

Compound 3, distribution coefficient: 2.2
Estimate against measurement, compound 3: 0.30 log units below; low and high end bracket the measured number.
By their numbers in this assay, from the lowest: compounds 2, 3 and 1 (each within the scatter of the next, the first and the last beyond it).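

At the carbonyl carbon whose other neighbour is the amide-type nitrogen, the exchange in this assay gives a number 0.30 log units lower from compound 1 to compound 3 (within the scatter), so the two groups cannot be told apart in this read-out. Among the compounds shown here, this is the first single-place exchange available, and it shows that 2-(fluoromethyl)-1,3-oxazol-4-yl, a five-membered aromatic ring with 2 hetero atoms, can take the place of 5-cyano-3-methylpyridin-2-yl, a six-membered aromatic ring with 1 hetero atom and a triple bond outside it, with no step beyond the scatter. No measurement at hand bears on a cause for this result.

Still open, from the compounds shown here alone, is how much of this outcome belongs to the 1,3-oxazol-4-yl ring and how much to its fluoromethyl group, a question that a plain methyl group or a hydrogen in place of fluoromethyl would address. Also open, going by these compounds, is whether the same reading holds for other groups on this carbonyl carbon, such as a phenyl ring or a morpholine, and for the same exchange on the core of compound 2.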